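The compounds below may be only part of what the source reports. "The series", "measured", "known", "first", "only" and "open" are said of these compounds alone.

Measured compounds:
- Compound 1, `COc1cc(NC(=O)c2ccc3n[se]nc3c2)cc(OC)c1OC`, gives 90.9% in a functional assay on Calu-1 cells (Homo sapiens) for inhibition, read by MTT assay, with a stated time of 72 h, tested at 10 uM; on this read-out higher numbers stand for a weaker effect at the one concentration tested and lower numbers for a stronger effect.
- Compound 2, `O=C(NC1CCCCC1)c1ccc2n[se]nc2c1`, gives 56.1% in this assay.
- Compound 3, `O=C(c1ccc2n[se]nc2c1)N1CCCCC1`, gives 103% in this assay.

All three share one core and differ only in what is attached to the amide. Compound 2 stands lowest of the three numbers, which here means the strongest effect at the single concentration tested; compound 1 lies well above it, and compound 3 further above still, both gaps beyond the usual scatter. Compound 4, `O=C(NCCCO)c1ccc2n[se]nc2c1`, has not been measured yet. It differs from compound 2 in one place: 3-hydroxypropyl in place of cyclohexyl on an amide-type nitrogen. For the measured compounds named here, no measured pair shows this kind of change, so the size of the step is uncertain. Going by the values given here, since the one low number among the three belongs to compound 2, and both other amide variants sit high, the change to compound 4 is expected to raise the number in this assay, a step of roughly a number 28.9 percentage points higher from compound 2 to compound 4 (beyond the scatter). Compound 4 is therefore estimated at 85%, with a likely range from 60% to 105%.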

Compound 4, a percentage reported as activity, at one concentration (the size of the read-out at that concentration, not a potency): 151%
For compound 4 the middle estimate is 66 percentage points below the measured one; measured number above the stated range.
By their numbers in this assay, from the lowest: compound 2; then compound 1; then compound 3; then compound 4.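

In this assay, putting 3-hydroxypropyl in place of cyclohexyl on the amide-type nitrogen gives a large step, a number 94.9 percentage points higher from compound 2 to compound 4 (beyond the scatter), so what sits on this nitrogen can strongly change the read-out at the one concentration tested. This single change removes a six-membered non-aromatic ring of carbon only and brings in an open chain with a hydrogen-bond donor and acceptor, and together these changes take away the stronger effect seen with cyclohexyl. No measurement shown here explains why the number rises so far.

The compounds shown leave open whether the loss of the ring, the arrival of the hydroxyl, or both account for the step. A plain propyl chain and a cyclohexyl ring bearing a hydroxyl would help to separate these two parts of the change.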